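The source may hold more compounds than are shown below. What is called first, only, known or untested is meant among the compounds shown, and "the series" means these compounds.

Two compounds of this series carry a measured number. Compound 1 `Cn1cc(-c2ccccc2NCC2=NCCN2)cn1` and compound 2 `c1ccc(-c2cn[nH]c2)c(NCC2=NCCN2)c1` share a core and differ only at an aromatic nitrogen. In a functional assay with Alpha-1A adrenergic receptor (Homo sapiens) as the target, read by calcium flux (a higher number here means a larger maximal response, a lower number a smaller maximal response), compound 1 gives 39%, while compound 2 gives 112%. Compound 2 therefore stands highest of the two numbers shown, and its nearest neighbour is compound 1, separated by a single step: a number 73 percentage points higher from compound 1 to compound 2 (beyond the scatter), a change well beyond the scatter. Compound 3 `CCn1cc(-c2ccccc2NCC2=NCCN2)cn1` has not yet been measured. It differs from compound 2 by ethyl in place of hydrogen on an aromatic nitrogen. Among the compounds with values here, the one measured step bears directly on this change, since it also concerns a hydrogen against an alkyl group on that same aromatic nitrogen, and it was large. Because that step, a number 73 percentage points higher from compound 1 to compound 2 (beyond the scatter), ran from alkyl to hydrogen and rose, the reverse direction here is expected to give a large fall in this assay. The expected step is a number 77 percentage points lower from compound 2 to compound 3 (beyond the scatter). Compound 3 is therefore estimated to give 35% in this assay, within a range of 10% to 70%.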

Compound 3, largest response reached (reported as maximal response), in percent of the reference or control that the assay uses: 0%
Beside the measured number, compound 3's estimate is 35 percentage points above it; measured number outside the range, below it.
By their numbers in this assay, from the lowest: compound 3; then compound 1; then compound 2.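

Moving from a hydrogen to an alkyl group on this aromatic nitrogen does more than lower the response in this assay by a fixed amount, since the length of the group also counts. Ethyl in place of hydrogen brings a number 112 percentage points lower from compound 2 to compound 3 (beyond the scatter) and so goes further than methyl did, while the single added carbon on its own accounts for a number 39 percentage points lower from compound 1 to compound 3 (beyond the scatter) in this same position. Across these three compounds the order runs from hydrogen through methyl to ethyl with no exception, and compound 3 at 0% marks the low end of the series, but no measurement at hand accounts for these steps.

The compounds shown leave open how a longer chain such as propyl, a branched group such as isopropyl, or a chain ending in a hydroxyl or an amine would behave on this nitrogen. They also leave open whether any group other than hydrogen at this place can reach the response of compound 2 at 112% in this assay.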